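One Change on Compound 1: Fluoro for Methoxy

A few compounds are considered here, and "the series" means these few. Any claim that something is new, unique, unknown or untested is made for them only; others in the source may bear on it.

Of the compounds shown here, three have been measured in a functional assay on OVCAR-3 cells (Homo sapiens) for inhibition, read by sulforhodamine B assay, with a stated time of 48 h; on this read-out lower numbers stand for stronger inhibition of growth and higher numbers for weaker inhibition of growth. Compound 1 `COc1ccc(-c2ccc(-c3ccc(C(=N)N)o3)o2)cc1` gives 920 nM, the lowest of the three numbers. Compound 2 `N=C(N)c1ccc(-c2ccc(-c3cncc4ccccc34)s2)s1` gives 1650 nM, which lies within the usual scatter of the number for compound 1. Compound 3 `COc1cc(OC)cc(-c2ccc(-c3ccc(C(=N)N)o3)o2)c1` gives 3260 nM, a gap to compound 1 that lies beyond the scatter. Compound 4 `N=C(N)c1ccc(-c2ccc(-c3ccc(F)cc3)o2)o1` has not been measured. It differs from compound 1 in one place: fluoro in place of methoxy on an aromatic carbon. Going by the values given here, no measured pair shows this change, so no step can be read from the numbers. In this assay a step of about the usual scatter, with no clear direction, is expected, namely a 1.3-fold higher number from compound 1 to compound 4 (0.12 log units; within the scatter). Compound 4 is thus expected to give about 1200 nM, in a range from 400 nM to 3600 nM.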

Compound 4, concentration for 50% growth inhibition: 1840 nM
Compound 4: the middle estimate sits 1.5-fold (0.19 log units) below what was measured; low and high end bracket the measured number.
By their numbers in this assay, from the lowest: compounds 1, 2, 4 and 3 (each within the scatter of the next, the first and the last beyond it).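

On an aromatic carbon para to a large group, putting fluoro in place of methoxy gives a 2.0-fold higher number from compound 1 to compound 4 (0.30 log units; within the scatter) in this assay. This position therefore tolerates the swap from methoxy, with its 2 heavy atoms and 1 hydrogen-bond acceptor, to fluoro, with 1 heavy atom and no hydrogen-bond acceptor, without a step beyond the usual scatter. This single pair gives no direction for the change.

As far as these compounds go, whether an amine or a carboxylic acid at this place would give a number beyond the scatter of compound 1 stays open. No other measurement bears on this result, so it remains unexplained.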